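Adding isobutyl to a sulfonamide nitrogen

The source may report more compounds than this note shows. Statements on the series, on what has been measured and on what is new or still open speak of the compounds shown alone.

- Compound 1 `CCc1ccc(N(CC2CCC2)S(=O)(=O)c2ccc3c(c2)C(=O)CC(C2CCOCC2)O3)cc1` gives 4.1
- Compound 2 `CCc1ccc(NS(=O)(=O)c2ccc3c(c2)C(=O)CC(C2CCOCC2)O3)cc1` gives 2.67

In a physicochemical assay for lipophilicity, at pH 7.4 (a higher number here means a more lipophilic compound, a lower number a more polar compound), compound 2 gives 2.67 and holds the lower of the two numbers. Compound 3 `CCc1ccc(N(CC(C)C)S(=O)(=O)c2ccc3c(c2)C(=O)CC(C2CCOCC2)O3)cc1` differs from compound 2 in one place. The change isobutyl in place of hydrogen on a sulfonamide nitrogen puts isobutyl in place of hydrogen on a sulfonamide nitrogen. Within the data shown here, one measured step bears on this, also on a sulfonamide nitrogen: a number 1.43 log units lower from compound 1 to compound 2 (beyond the scatter) when hydrogen replaces cyclobutylmethyl. Run in reverse, that large step suggests a similarly large rise in this assay is expected here. The expected step is a number 1.23 log units higher from compound 2 to compound 3 (beyond the scatter) and rests on this single comparison. For compound 3 the estimated value is 3.9 with 3.5 to 4.3 as the expected range.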

Compound 3, distribution coefficient: 4.21
Beside the measured number, compound 3's estimate is 0.31 log units below it; the range from low to high includes it.
By their numbers in this assay, from the lowest: compound 2; then compounds 1 and 3 (each within the scatter of the next).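

Isobutyl in place of hydrogen on the sulfonamide nitrogen gives a number 1.54 log units higher from compound 2 to compound 3 (beyond the scatter) in this assay and so shows that the large difference seen with cyclobutylmethyl is not confined to that one group. Isopropyl in place of cyclobutyl on the saturated chain carbon gives a number 0.11 log units higher from compound 1 to compound 3 (within the scatter) and so leaves these two substituents indistinguishable in this measurement. Nothing available explains these results.

From the compounds shown here alone, whether a smaller group such as methyl gives a smaller step remains open. So does how a chain carrying an amine or a carboxylic acid would read at this nitrogen.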